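Methyl on the Saturated Ring Carbon: Compound 3 to Compound 4

This account rests on a few compounds, and the source may have more. Where it says the series, first, only, none or still open, it means among the compounds named here.

In an ADME assay on the whole organism for metabolic stability, with Rattus norvegicus as the target, at a dose of 5 mg/kg by the intravenous route (on this read-out higher numbers stand for a longer-lived compound and lower numbers for a shorter-lived compound), compound 1 `COc1c(-c2ccc3c(c2)CC=C3CNS(C)(=O)=O)cc(-n2ccc(=O)[nH]c2=O)cc1C(C)(C)C` gives 1.9 h, compound 2 `COc1c(-c2ccc3c(CNS(C)(=O)=O)csc3c2)cc(-n2ccc(=O)[nH]c2=O)cc1C(C)(C)C` gives 3.6 h, and compound 3 `COc1c(-c2ccc3c(c2)CCC3CNS(C)(=O)=O)cc(-n2ccc(=O)[nH]c2=O)cc1C(C)(C)C` gives 1.8 h. Compound 3 thus shows the smallest of the three numbers, but its gap to compound 1 and its gap to compound 2 both lie within the usual scatter, so no real difference among the three is established. Compound 4 `COc1c(-c2ccc3c(c2)CCC3(C)CNS(C)(=O)=O)cc(-n2ccc(=O)[nH]c2=O)cc1C(C)(C)C` differs from compound 3 by methyl in place of hydrogen on a saturated ring carbon. No comparable change occurs among the measured compounds, so the expectation for compound 4 rests on compound 3 alone. A step from compound 3 to compound 4 of about a 1.2-fold higher number from compound 3 to compound 4 (0.09 log units; within the scatter) is expected, which would remain within the scatter. Compound 4 is therefore estimated at 2.2 h, between 1.1 h and 4.5 h.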

Compound 4, half-life: 2.3 h
Compound 4: middle estimate off by 1.0-fold (0.02 log units), on the low side, within the range that was stated.
By their numbers in this assay, from the lowest: compounds 3, 1, 4 and 2 (each within the scatter of the next).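

Within the data shown here, this is the first pair to isolate a single change. In this assay, methyl in place of hydrogen on a saturated ring carbon gives a 1.3-fold higher number from compound 3 to compound 4 (0.11 log units; within the scatter), so the half-lives of the pair cannot be told apart and this carbon carries the methyl without a difference beyond the scatter. No measurement shown bears on why the two compounds read alike. On these data alone, whether an ethyl, a hydroxyl or an amine on this carbon would also stay within the scatter remains open. So does whether a second methyl on the same five-membered ring would.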